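Substituent changes on the aryl triazole of a camphor-derived lactam

The source may hold more compounds than are shown below. What is called first, only, known or untested is meant among the compounds shown, and "the series" means these compounds.

Measured so far:
Compound 1, `CC1(C)[C@H]2CC[C@]1(C)N(Cc1cn(-c3ccccc3Br)nn1)C(=O)C2`: 140 nM
Compound 2, `CC1(C)[C@H]2CC[C@]1(C)N(Cc1cn(-c3ccccc3C#N)nn1)C(=O)C2`: 110 nM
Compound 3, `CC1(C)[C@H]2CC[C@]1(C)N(Cc1cn(-c3cccc(C#N)c3)nn1)C(=O)C2`: 230 nM

All three were tested in a functional assay on OVCAR-3 cells (Homo sapiens) for inhibition, read by MTT assay, with a stated time of 24 h; a higher number here means a weaker inhibitor, a lower number a stronger inhibitor. Compound 1 stands second highest of the three numbers; its nearest neighbour is compound 2, reached by a 1.3-fold lower number from compound 1 to compound 2 (0.10 log units; within the scatter), and its furthest is compound 3, reached by a 1.6-fold higher number from compound 1 to compound 3 (0.22 log units; within the scatter). Between the two cyano isomers there is a 2.1-fold higher number from compound 2 to compound 3 (0.32 log units; beyond the scatter).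

Compound 4, `Cc1cccc(-n2cc(CN3C(=O)C[C@@H]4CC[C@@]3(C)C4(C)C)nn2)c1`, has not yet been measured. It differs from compound 1 as follows: 3-methylphenyl in place of 2-bromophenyl on an aromatic nitrogen.

For the measured compounds named here, two measured steps bear on this change. The move from 2-bromophenyl to 3-cyanophenyl, a 1.6-fold higher number from compound 1 to compound 3 (0.22 log units; within the scatter), and the move from 2-cyanophenyl to 3-cyanophenyl, a 2.1-fold higher number from compound 2 to compound 3 (0.32 log units; beyond the scatter), both point the same way, toward a somewhat higher number. Going by the values given here, no measured compound carries a methyl group, so that part of the change is uncertain. Compound 4 is therefore expected to show a 1.5-fold higher number from compound 1 to compound 4 (0.18 log units; within the scatter) in this assay. The estimated value for compound 4 is 210 nM, with a range from 100 nM to 450 nM.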

Compound 4, half-maximal inhibitory concentration: 160 nM
Compound 4: the middle estimate sits 1.3-fold (0.12 log units) above what was measured, and the stated range covers the measured number.
By their numbers in this assay, from the lowest: compounds 2, 1, 4 and 3 (each within the scatter of the next, the first and the last beyond it).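

In this assay, for the compounds shown here, a methyl group is the first substituent on the phenyl ring that is neither a halogen nor a nitrile, and 3-methylphenyl in place of 2-bromophenyl on the aromatic nitrogen leaves compound 4 level with compound 1, with a 1.1-fold higher number from compound 1 to compound 4 (0.06 log units; within the scatter). Methyl in place of cyano on an aromatic carbon likewise gives no readable difference, with a 1.4-fold lower number from compound 3 to compound 4 (0.16 log units; within the scatter), and compound 4 also cannot be told apart from the 2-cyanophenyl compound, with a 1.5-fold higher number from compound 2 to compound 4 (0.16 log units; within the scatter), although the 3-cyanophenyl compound could be, with a 2.1-fold higher number from compound 2 to compound 3 (0.32 log units; beyond the scatter). Nothing available accounts for these results.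

The compounds shown leave open how an amine or a carboxylic acid on the phenyl ring would read here. They also leave open whether 2-methylphenyl would match 3-methylphenyl.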